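The source may hold more compounds than are shown below. What is called first, only, known or untested is meant among the compounds shown, and "the series" means these compounds.

Three close relatives built on one shared core have been tested in a functional assay on OVCAR-5 cells (Homo sapiens) for cytotoxicity, read by sulforhodamine B assay, with a stated time of 48 h; on this read-out lower numbers stand for stronger inhibition of growth and higher numbers for weaker inhibition of growth. Compound 1 `ClCc1ccc(Cn2cnc3c(Cl)ncnc32)cc1` gives 2950 nM. Compound 2 `ClCc1cccc(Cn2cnc3ncnc(Cl)c32)c1` gives 6760 nM. Compound 3 `ClCc1ccc(Cn2cnc3c(Cl)nc(Cl)nc32)cc1` gives 18200 nM.

Among these three numbers compound 2 stands second highest. Its number is higher than that of compound 1 and lower than that of compound 3, and both of these gaps lie beyond the usual scatter of repeated measurements, so compound 2 sits clearly in the middle of the group.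

Compound 4 `ClCc1cccc(Cn2cnc3nc(Cl)nc(Cl)c32)c1` is not yet measured. It differs from compound 2 in one place: chloro in place of hydrogen on an aromatic carbon. The new chloro sits on an aromatic carbon of a six-membered aromatic ring with two nitrogen atoms, between two ring nitrogen atoms, within the fused two-ring part of the core.

Within the data shown here, one measured step bears directly on this change. The same exchange of hydrogen for chloro on the core, going from compound 1 to compound 3, produced a 6.2-fold higher number from compound 1 to compound 3 (0.79 log units; beyond the scatter), that is, a clearly weaker inhibition of growth. A step of the same direction and of roughly the same size is therefore expected here, a 5.0-fold higher number from compound 2 to compound 4 (0.70 log units; beyond the scatter). On that basis compound 4 is estimated to give about 34000 nM, with a likely range from 14000 nM to 80000 nM.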

Compound 4, concentration for 50% growth inhibition: 1690 nM
For compound 4 the middle estimate is 20-fold (1.30 log units) above the measured one; the whole stated range lies above it.
By their numbers in this assay, from the lowest: compounds 4 and 1 (each within the scatter of the next); then compound 2; then compound 3.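

The chloro on the aromatic carbon between two ring nitrogen atoms turns out to have no single, transferable effect in this assay: the direction of the change depends on the rest of the molecule. The exchange of hydrogen for chloro that weakened growth inhibition in the earlier pair strengthens it here, with a 4.0-fold lower number from compound 2 to compound 4 (0.60 log units; beyond the scatter), so the same change cannot be assumed to act alike on these two related cores: the same change on two cores in this assay, a 6.2-fold higher number (0.79 log units; beyond the scatter) from compound 1 to compound 3 and a 4.0-fold lower number (0.60 log units; beyond the scatter) from compound 2 to compound 4, 25-fold (1.39 log units) apart, beyond the scatter of two such steps The two pairs differ from each other in more than one place, so these compounds cannot show which of those differences goes with the reversal.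

On these data alone, it remains open whether the reversal is tied to chloro itself or would also appear with an amine or a methoxy group on this same aromatic carbon of both cores. As far as these compounds go, it is equally open whether the opposite directions would persist if a hydroxymethyl group took the place of the chloromethyl group in both pairs.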